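The compounds below may be only part of what the source reports. "The series", "measured", "known", "first", "only" and "open" are said of these compounds alone.

Of the compounds shown here, three on a shared core have been measured in a physicochemical assay for lipophilicity; on this read-out lower numbers stand for lower lipophilicity and higher numbers for higher lipophilicity: compound 1 (`C[C@H]1CC[C@@H]2[C@@H](OC(=O)[C@]23CC(c2ccc(Cl)cc2)N(c2ccccc2)O3)[C@]2(C)C(=O)C=C[C@@]12O`) gives 3.87, compound 2 (`C[C@H]1CC[C@@H]2[C@@H](OC(=O)[C@]23CC(c2ccc(C#N)cc2)N(c2ccccc2)O3)[C@]2(C)C(=O)C=C[C@@]12O`) gives 2.94 and compound 3 (`Cc1ccc(C2C[C@@]3(ON2c2ccccc2)C(=O)O[C@@H]2[C@H]3CC[C@H](C)[C@]3(O)C=CC(=O)[C@@]23C)cc1`) gives 3.64. Compound 3 thus lies within the scatter of compound 1 and clearly higher than compound 2. Compound 4 (`C[C@H]1CC[C@@H]2[C@@H](OC(=O)[C@]23CC(c2ccccc2)N(c2ccccc2)O3)[C@]2(C)C(=O)C=C[C@@]12O`) has hydrogen in place of methyl on an aromatic carbon. For the measured compounds named here, no measured step makes this exact change. The closest evidence comes from swaps at the same place: a number 0.93 log units lower from compound 1 to compound 2 (beyond the scatter), a number 0.23 log units lower from compound 1 to compound 3 (within the scatter) and a number 0.70 log units higher from compound 2 to compound 3 (beyond the scatter). Given steps of that size, a small downward move is expected, a number 0.34 log units lower from compound 3 to compound 4 (beyond the scatter). Compound 4 is estimated at 3.3, with an expected range from 2.95 to 3.65.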

Compound 4, partition coefficient: 3.19
Estimate against measurement, compound 4: 0.11 log units above, and the stated range covers the measured number.
By their numbers in this assay, from the lowest: compounds 2 and 4 (each within the scatter of the next); then compounds 3 and 1 (each within the scatter of the next).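

With hydrogen now at this place, the methyl, chloro and cyano groups can each be set against the unsubstituted ring in this assay. Hydrogen in place of methyl gives a number 0.45 log units lower from compound 3 to compound 4 (beyond the scatter) and hydrogen in place of chloro gives a number 0.68 log units lower from compound 1 to compound 4 (beyond the scatter), both beyond the scatter, whereas hydrogen in place of cyano gives a number 0.25 log units higher from compound 2 to compound 4 (within the scatter) and stays within it. Nothing measured here gives a reason for these differences. The compounds shown leave open how an amine, a carboxylic acid or a longer chain on this aromatic carbon, para to a large group, would compare with hydrogen.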